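The source may hold more compounds than are shown below. What is called first, only, known or untested is meant among the compounds shown, and "the series" means these compounds.

Measured compounds in a functional assay (B cells) with Mus musculus as the target; a higher number here means that more compound is needed for the effect, a lower number that less compound is needed:
- compound 1 `CN(C)CCCn1c(=O)n(C2OC(CO)[C@@H](O)[C@H]2O)c2nc(N)nc(O)c21`: 194 uM
- compound 2 `CCOC(=O)Cn1c(=O)n(C2OC(CO)[C@@H](O)[C@H]2O)c2nc(N)nc(O)c21`: 48 uM

Going by the values given here, compound 2 holds the lowest of the two numbers in this assay so far; its nearest neighbour is compound 1, and the one measured step, a 4.0-fold lower number from compound 1 to compound 2 (0.61 log units; beyond the scatter), is a modest one beyond the scatter. Both compounds share the same core, and they differ only in the group on the saturated chain carbon bound to the aromatic nitrogen.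

Compound 3 `N#Cc1ccc(Cn2c(=O)n(C3OC(CO)[C@@H](O)[C@H]3O)c3nc(N)nc(O)c32)cc1` carries the change (4-cyanophenyl in place of ethoxycarbonyl on a saturated chain carbon bound to an aromatic nitrogen); cut one bond further out, the same difference reads (ethoxycarbonyl)methyl to 4-cyanobenzyl. Among the compounds with values here, no measured step covers this change. Within the data shown here, the only step available, a 4.0-fold lower number from compound 1 to compound 2 (0.61 log units; beyond the scatter), shows that swapping the group at this position moves the number in this assay by a modest amount, but it involves neither of the groups exchanged here, so it gives direction only loosely. The expectation is therefore a step of roughly that size or smaller, with no firm direction; a small further improvement is the working guess. For compound 3 the estimate in this assay is 40 uM (range 12 uM to 130 uM), which would be an expected step of a 1.2-fold lower number from compound 2 to compound 3 (0.08 log units; within the scatter).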

Compound 3, concentration for half-maximal effect: 15 uM
The estimate for compound 3 lay 2.7-fold (0.43 log units) above the measured number; the measured number falls inside the stated range.
By their numbers in this assay, from the lowest: compound 3; then compound 2; then compound 1.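

In this assay, 4-cyanophenyl in place of ethoxycarbonyl on a saturated chain carbon bound to an aromatic nitrogen gives a 3.2-fold lower number from compound 2 to compound 3 (0.51 log units; beyond the scatter) and so lowers the number beyond the scatter. Going by these compounds alone, this is the first sign that a group with a six-membered aromatic ring of carbon only and a nitrile is tolerated here, since both earlier groups have no ring. The same position now covers a wider span, with a 13-fold lower number from compound 1 to compound 3 (1.11 log units; beyond the scatter) as a large step where only a modest one was known before, and the three groups order as 4-cyanophenyl, then ethoxycarbonyl, then 2-(dimethylamino)ethyl. No supporting data bear on why the number falls with this change.

The three compounds do not separate the contribution of the aromatic ring from that of the nitrile, a question that a plain phenyl group at this place would address. They also leave open how a carboxylic acid in place of the ethoxycarbonyl, or a longer chain between the aromatic nitrogen and the 4-cyanophenyl, would read in this assay on the same core.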